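Replacing an aryl amide group near the assay limit

The compounds below may be only part of what the source reports. "The series", "measured", "known", "first", "only" and "open" are said of these compounds alone.

- Compound 1 `CCn1c(C(=O)N(CCC#N)CCC#N)ccc1C(CC)(CC)c1ccc(OCCC(O)(CC)CC)c(C)c1`: 46300 nM
- Compound 2 `CCOc1ccc(NC(=O)c2ccc(C(CC)(CC)c3ccc(OCCC(O)(CC)CC)c(C)c3)n2CC)cc1`: > 50000 nM

In a functional assay on HepG2 cells (Homo sapiens) for antiproliferative activity, read by MTT assay, with a stated time of 48 h (on this read-out higher numbers stand for weaker inhibition and lower numbers for stronger inhibition), compound 2 gives > 50000 nM, which is a limit of the assay and not a number. Compound 3 `CCC(C)C(NC(=O)c1ccc(C(CC)(CC)c2ccc(OCCC(O)(CC)CC)c(C)c2)n1CC)C(=O)OC` differs from compound 2 by one change: a group of 9 heavy atoms (7 carbon, 2 oxygen; no ring) in place of a group of 9 heavy atoms (8 carbon, 1 oxygen; one six-membered aromatic ring of carbon only), on an amide-type nitrogen. Among the compounds with values here, the only measured step that bears on this is an at least 1.0-fold higher number from compound 1 to compound 2 (0.03 log units; that floor lies within the scatter). Compound 1, whose group on the carbonyl carbon also has no ring, gives 46300 nM, so no change beyond the scatter is expected. The expected step is an at least 1.2-fold lower number from compound 2 to compound 3 (0.09 log units; that floor lies within the scatter). For compound 3, the estimated value is 40000 nM, with an expected range from 15000 nM to 70000 nM.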

Compound 3, half-maximal inhibitory concentration: > 50000 nM
Compound 3: no number, only a limit; the forecaster's own chance of this, stated with the estimate: 55%; at least 1.2-fold (0.09 log units) between middle value and limit.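

In this assay compound 3 gives > 50000 nM, a limit of the assay and not a number, so a group with no ring on the amide-type nitrogen yields no measured value here, just as 4-ethoxyphenyl did. Within the data shown here, the step between compound 2 and compound 3 cannot be read, and the one readable step is an at least 1.0-fold higher number from compound 1 to compound 3 (0.03 log units; that floor lies within the scatter). The three compounds thus crowd at one end of the range: the limit of > 50000 nM in this assay, at which 2 of the 3 values shown sit.

As far as these compounds go, whether an amine-bearing chain or a carboxylic acid on the amide-type nitrogen would give a clearly lower number stays open.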